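Benzodioxinylmethyl replaces methoxybenzyl on the sulfonamide chain

The source may hold more compounds than are shown below. What is called first, only, known or untested is meant among the compounds shown, and "the series" means these compounds.

Three analogues on a shared core are in hand: compound 1 `O=S(=O)(NCCCNCc1cccc2ccccc12)c1cc(C(F)(F)F)cc(C(F)(F)F)c1`, compound 2 `CC(C)(C)c1ccc(CNCCCNS(=O)(=O)c2cc(C(F)(F)F)cc(C(F)(F)F)c2)cc1` and compound 3 `COc1cccc(CNCCCNS(=O)(=O)c2cc(C(F)(F)F)cc(C(F)(F)F)c2)c1`. In a functional assay on Capan-2 cells (Homo sapiens) for inhibition, read by MTT assay, with a stated time of 72 h (a lower number here means a stronger inhibitor of growth, a higher number a weaker inhibitor of growth), compound 1 gives 2700 nM, compound 2 gives 2100 nM and compound 3 gives 6400 nM. Compound 3 thus carries the highest of the three numbers: the step of a 2.4-fold higher number from compound 1 to compound 3 (0.37 log units; beyond the scatter) and the step of a 3.0-fold higher number from compound 2 to compound 3 (0.48 log units; beyond the scatter) both exceed the scatter, whereas a 1.3-fold lower number from compound 1 to compound 2 (0.11 log units; within the scatter) does not. Compound 4 `O=S(=O)(NCCCNCC1COc2ccccc2O1)c1cc(C(F)(F)F)cc(C(F)(F)F)c1` is the next member and differs from compound 3 as follows: 2,3-dihydro-1,4-benzodioxin-2-yl in place of 3-methoxyphenyl on a saturated chain carbon bound to an amine nitrogen. For the measured compounds named here, no measured step contains the entering group, so the two steps into compound 3 are the only guide; both show that exchanging the aryl group on the chain shifts the number modestly, but they give no direction for this particular group. A modest step either way is therefore plausible, and the estimate sits near compound 3 with a wide range. Compound 4 is estimated at 4000 nM, between 1300 nM and 12000 nM, corresponding to an expected step of a 1.6-fold lower number from compound 3 to compound 4 (0.20 log units; within the scatter).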

Compound 4, concentration for 50% growth inhibition: 2500 nM
Compound 4: middle estimate off by 1.6-fold (0.20 log units), on the high side, and the stated range covers the measured number.
By their numbers in this assay, from the lowest: compounds 2, 4 and 1 (each within the scatter of the next); then compound 3.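

Working notes: in this assay, the (2,3-dihydro-1,4-benzodioxin-2-yl)methyl group lowers the number relative to 3-methoxybenzyl, with a 2.6-fold lower number from compound 3 to compound 4 (0.41 log units; beyond the scatter), so this position also accepts a group whose ring on the chain carbon is non-aromatic and holds 2 hetero atoms. For the compounds shown here, the two other steps, a 1.2-fold higher number from compound 2 to compound 4 (0.08 log units; within the scatter) and a 1.1-fold lower number from compound 1 to compound 4 (0.03 log units; within the scatter), place compound 4 level with compound 1 and compound 2, leaving compound 3 as the only member of the four set apart by its higher number. No measurement shown explains the step from 3-methoxyphenyl to the benzodioxinyl group.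

Still open, from the compounds shown here alone, is whether the two ring oxygens of compound 4 matter at all, which a 1,2,3,4-tetrahydronaphthalen-2-yl group in the same place would test. The compounds shown also leave open how a plain cyclohexyl group or a longer chain between the amine nitrogen and the ring would read in this assay.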